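The source may hold more compounds than are shown below. What is called first, only, known or untested is meant among the compounds shown, and "the series" means these compounds.

Three compounds that share one core differ only in the aryl group attached to the carbonyl carbon. Compound 1 `COc1cc(-c2nnc3n2NC(c2ccco2)C(C(=O)c2cccs2)S3)cc(OC)c1OC` carries thiophen-2-yl, compound 2 `COc1cc(-c2nnc3n2NC(c2ccco2)C(C(=O)c2ccccc2)S3)cc(OC)c1OC` carries phenyl, and compound 3 `COc1cc(-c2nnc3n2NC(c2ccco2)C(C(=O)c2ccc(C)cc2)S3)cc(OC)c1OC` carries 4-methylphenyl. In a functional assay on MCF7 cells (Homo sapiens) for cytotoxicity, read by MTT assay, with a stated time of 48 h (on this read-out higher numbers stand for weaker inhibition and lower numbers for stronger inhibition), compound 1 gives > 100000 nM, which is a limit of the assay rather than a number. In this assay compound 2 gives 39800 nM. In this assay compound 3 gives > 100000 nM, again a limit rather than a number, so compound 3 stands at the weak end of what is shown (the limit of > 100000 nM in this assay, at which 2 of the 3 values shown sit).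

Compound 4 `COc1cc(-c2nnc3n2NC(c2ccco2)C(C(=O)c2ccc(F)c(F)c2)S3)cc(OC)c1OC` differs from compound 3 by 3,4-difluorophenyl in place of 4-methylphenyl on a carbonyl carbon. For the measured compounds named here, two measured steps bear on it: an at least 2.5-fold lower number from compound 1 to compound 2 (0.40 log units; beyond the scatter) and an at least 2.5-fold higher number from compound 2 to compound 3 (0.40 log units; beyond the scatter), both at least modest, while a step that the two limits leave unreadable from compound 1 to compound 3. No measured step introduces fluorine, so the direction of the change is not settled by what is shown. Compound 4 is therefore expected to land near the range marked by compound 2 and compound 3, with the step of an at least 1.2-fold lower number from compound 3 to compound 4 (0.09 log units; that floor lies within the scatter) expected to be small. The estimate for compound 4 in this assay is 80000 nM, between 25000 nM and 300000 nM.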

Compound 4, half-maximal inhibitory concentration: 73200 nM
Estimate against measurement, compound 4: 1.1-fold (0.04 log units) above, within the range that was stated.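

Compound 4 is the only compound shown with fluorine on the aryl group at this carbonyl carbon, and it gives a second readable number in this assay. Set against plain phenyl, 3,4-difluorophenyl makes no clear difference, with a 1.8-fold higher number from compound 2 to compound 4 (0.26 log units; within the scatter). Against the other two groups the change reads only as a floor, with an at least 1.3-fold lower number from compound 3 to compound 4 (0.13 log units; that floor lies within the scatter) and an at least 1.3-fold lower number from compound 1 to compound 4 (0.13 log units; that floor lies within the scatter), and the true size of each step stays unknown because compound 1 and compound 3 rest on a limit: the limit of > 100000 nM in this assay, at which 2 of the 4 values shown sit.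

Going by these compounds, whether an aryl group carrying an amine or a carboxylic acid would move the number beyond the scatter from compound 2, and in which direction, stays open. So does whether a single fluorine would behave like the two in compound 4.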